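The source may hold more compounds than are shown below. What is called first, only, known or untested is meant among the compounds shown, and "the series" means these compounds.

Measured in a functional assay on K562 cells (Homo sapiens) for antiproliferative activity, read by sulforhodamine B assay, with a stated time of 48 h; on this read-out higher numbers stand for weaker inhibition and lower numbers for stronger inhibition:
- compound 1 `O=C(NCCCNc1cc(-c2cn(-c3ccccc3)nc2-c2cccc(O)c2)ccn1)Nc1ccc(F)cc1`: 810 nM
- compound 2 `O=C(NCCCNc1cc(-c2cn(-c3ccccc3)nc2-c2cccc(O)c2)ccn1)Nc1cccc(C(F)(F)F)c1`: 1260 nM

Compound 1 has only compound 2 for comparison, and the two sit within the scatter of each other: a 1.6-fold higher number from compound 1 to compound 2 (0.19 log units; within the scatter). Compound 3 `COc1cccc(-c2nn(-c3ccccc3)cc2-c2ccnc(NCCCNC(=O)Nc3ccc(F)cc3)c2)c1` keeps the 4-fluorophenyl group of compound 1 and differs from it at another place: methyl in place of hydrogen on an oxygen on an aromatic ring, turning hydroxy to methoxy. That single measured step swaps a group on an amide-type nitrogen, so it does not touch this oxygen and offers only a loose guide to size. No measurement fixes a direction in this assay, so only a modest drift to a higher number is expected, with no firm step beyond the scatter. The expected step is a 1.7-fold higher number from compound 1 to compound 3 (0.24 log units; within the scatter). For compound 3 the estimated value is 1400 nM, with an expected range of 500 nM to 4000 nM.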

Compound 3, half-maximal inhibitory concentration: 2960 nM
For compound 3 the middle estimate is 2.1-fold (0.33 log units) below the measured one, within the range that was stated.
By their numbers in this assay, from the lowest: compounds 1 and 2 (each within the scatter of the next); then compound 3.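

In this assay, the change from hydroxy to methoxy on the 3-hydroxyphenyl group gives a 3.7-fold higher number from compound 1 to compound 3 (0.56 log units; beyond the scatter) and is the first single change shown to move the number beyond the scatter, though only modestly. The earlier swap on the amide-type nitrogen gave a 1.6-fold higher number from compound 1 to compound 2 (0.19 log units; within the scatter) and so did not separate its two compounds. This oxygen is therefore the one place among those shown where a change of a single methyl registers, but nothing measured here explains the shift.

The compounds shown leave open whether the hydrogen that leaves or the methyl that enters accounts for the step, which an amine or an ethoxy group at this place could help to separate. They also leave open whether the same change would give a similar step with the 3-(trifluoromethyl)phenyl group of compound 2 in place.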